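Phosphate to Amino Acid in a Styryl Sulfonamide Series

The compounds below may be only part of what the source reports. "The series", "measured", "known", "first", "only" and "open" are said of these compounds alone.

The account rests on three measured compounds. Compound 1 `COc1ccc(NS(=O)(=O)/C=C/c2c(F)c(F)c(F)c(F)c2F)cc1N` gives 75000 nM in a functional assay on K562 cells (Homo sapiens) for cytotoxicity, read by trypan blue exclusion, with a stated time of 96 h; a lower number here means a stronger inhibitor, a higher number a weaker inhibitor. Compound 3 `COc1ccc(NS(=O)(=O)/C=C/c2cc(OC)c(OC)c(OC)c2)cc1N` gives 15000 nM in this assay, and compound 2 `COc1cc(OC)c(/C=C/S(=O)(=O)Nc2ccc(OC)c(OP(=O)(O)O)c2)c(OC)c1` gives 7.5 nM in this assay. Compound 2 thus stands lowest of the three numbers, with compound 3 nearest and compound 1 furthest, both gaps lying beyond the scatter. No pair among these three differs in only one place, so no single step between measured compounds can be read off.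

The step followed here goes from compound 2 to compound 4 `COc1cc(OC)c(/C=C/S(=O)(=O)Nc2ccc(OC)c(NC(C(=O)O)c3ccc(F)cc3)c2)c(OC)c1`, which has not yet been measured. The change is a group of 12 heavy atoms (8 carbon, 1 nitrogen, 2 oxygen, 1 fluorine; one six-membered aromatic ring of carbon only) in place of a group of 5 heavy atoms (4 oxygen, 1 phosphorus; no ring), on an aromatic carbon. The group that leaves has no ring; the group that enters, (carboxy(4-fluorophenyl)methyl)amino, carries one six-membered aromatic ring of carbon only and sits ortho to a methoxy group and meta to a large group.

Within the data shown here, with no measured step of this kind to lean on, the expected size of the move in this assay is uncertain; a modest rise in the number, within or somewhat beyond the scatter, seems the most likely outcome. Compound 4 is estimated at 30 nM, with a range from 4 nM to 250 nM, which means an expected step of a 4.0-fold higher number from compound 2 to compound 4 (0.60 log units; beyond the scatter).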

Compound 4, half-maximal inhibitory concentration: 20 nM
Estimate against measurement, compound 4: 1.5-fold (0.18 log units) above; low and high end bracket the measured number.
By their numbers in this assay, from the lowest: compound 2; then compound 4; then compound 3; then compound 1.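

In this assay, placing (carboxy(4-fluorophenyl)methyl)amino on the aromatic carbon ortho to a methoxy group, in place of the phosphate group, gives a 2.7-fold higher number from compound 2 to compound 4 (0.43 log units; beyond the scatter) and so a modest loss beyond the scatter. Among these compounds, this is the first single-place comparison, and it shows that the phosphorus-containing group is not needed at this position for a number close to that of compound 2, even though the entering group is larger and carries a six-membered aromatic ring of carbon only. The data offer no measured property that would account for the size of this step.

The compounds shown do not separate the contributions of the parts of the entering group, so it remains open how the number would respond to a methyl ester in place of the carboxylic acid, or to hydrogen or chlorine in place of the fluorine. Also open, from the compounds shown here alone, is whether a simple amine or a glycine side chain at this carbon, on the same core, would give a number nearer that of compound 2 or further from it.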